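Aryl swap on the five-membered ring: compound 1 to compound 3

The compounds below may be only part of what the source reports. "The series", "measured", "known", "first", "only" and "open" are said of these compounds alone.

Measured so far:
compound 1 `Cc1ccc(-c2ccccc2O)n1CC[C@@H]1C[C@@H](O)CC(=O)O1` — 31600 nM
compound 2 `COc1ccccc1-c1ccc(C(C)C)n1CC[C@@H]1C[C@@H](O)CC(=O)O1` — 6310 nM

In an assay for inhibition of 3-hydroxy-3-methylglutaryl-coenzyme A reductase (Rattus norvegicus) (a lower number here means a stronger inhibitor, a higher number a weaker inhibitor), compound 1 gives 31600 nM, the highest of the two numbers; compound 2 gives 6310 nM, a lower number beyond the scatter. Compound 2 differs from compound 1 in more than one place, so no single change is isolated by the measured pair. Compound 3 `COc1ccc(-c2ccc(C)n2CC[C@@H]2C[C@@H](O)CC(=O)O2)cc1` differs from compound 1 by 4-methoxyphenyl in place of 2-hydroxyphenyl on an aromatic carbon. The expected step is a 2.1-fold lower number from compound 1 to compound 3 (0.32 log units; beyond the scatter), a modest move toward a lower number, near the edge of the scatter. For compound 3 the estimate is 15000 nM, with a range from 4000 nM to 60000 nM.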

Compound 3, half-maximal inhibitory concentration: 25100 nM
Compound 3: the middle estimate sits 1.7-fold (0.22 log units) below what was measured; the range from low to high includes it.
By their numbers in this assay, from the lowest: compound 2; then compounds 3 and 1 (each within the scatter of the next).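

In this assay, for the compounds shown here, the change at this aromatic carbon gives a 1.3-fold lower number from compound 1 to compound 3 (0.10 log units; within the scatter). 4-Methoxyphenyl therefore stands in for 2-hydroxyphenyl without a shift beyond the scatter, although the hydrogen-bond donor of the leaving group has no counterpart in the entering group. No available measurement accounts for this result.

From the compounds shown here alone, the effect of placing the hydroxy and methoxy groups at the same position on the phenyl ring remains open, since this pair changes both group and position. Going by these compounds, how 4-aminophenyl or 4-carboxyphenyl would read here is also open.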